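The compounds below may be only part of what the source reports. "The series", "measured", "known", "first", "only" and "open" are said of these compounds alone.

Among the measured compounds shown here, in an ADME assay on microsomes from liver (Homo sapiens) for metabolic stability, read by LC-MS, using NADPH, with stated times of 5 min and 30 min, tested at 1 uM (a lower number here means that less of the compound is left, a higher number that more of the compound is left), compound 1 `O=C(O)c1ccc(-n2cc(C(=O)c3c(Cl)cccc3Cl)c3cccnc32)cc1` gives 100%, the highest of the three numbers measured so far. Compound 3 `O=C(O)c1ccc(-n2cc(C(=O)c3c(Cl)cccc3Cl)c3ncccc32)cc1` gives 94%, which lies within the usual scatter of compound 1. Compound 2 `Cc1cccc(Cl)c1C(=O)c1cn(-c2ccc(C(=O)O)cc2F)c2ncccc12` gives 88%, a number that falls beyond the scatter below compound 1. Compound 4 `O=C(O)c1ccc(-n2cc(C(=O)c3c(Cl)cccc3C(F)(F)F)c3cccnc32)cc1` is not yet measured; it differs from compound 1 in a single place: trifluoromethyl in place of chloro on an aromatic carbon. For the measured compounds named here, no pair of measured compounds shows what this change does in this assay, so only a modest expectation can be formed. Compound 1 gives 100% and all measured numbers sit high, so the expected step of a number 6 percentage points lower from compound 1 to compound 4 (within the scatter) is small, within the scatter. Compound 4 is therefore estimated at 94%, with a range from 80% to 100%.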

Compound 4, percent of the compound remaining: 83%
Compound 4: the middle estimate sits 11 percentage points above what was measured; measured number inside the range.
By their numbers in this assay, from the lowest: compounds 4, 2, 3 and 1 (each within the scatter of the next, the first and the last beyond it).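

In this assay, the series now has its first comparison that differs in one place: trifluoromethyl in place of chloro on this aromatic carbon, ortho to a large group, gives a number 17 percentage points lower from compound 1 to compound 4 (beyond the scatter). Among the compounds shown here, the read-out is therefore sensitive to which group sits at this position, something the earlier compounds could not show. No measurement at hand accounts for the step.

From the compounds shown here alone, whether other groups here, such as a nitrile or a methoxy group, would give a similar step remains open. So does whether the same change would give a similar step on the core of compound 3.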